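The source may report more compounds than this note shows. Statements on the series, on what has been measured and on what is new or still open speak of the compounds shown alone.

Compound 1 `O=C1/C(=C\c2ccccc2)c2c(ncn2COCc2ccccc2)CCN1Cc1ccc(-c2ccccc2)cc1`: 18300 nM
Compound 2 `Cc1ccccc1CN1CCc2ncn(COCc3ccccc3)c2/C(=C/c2ccccc2)C1=O`: 25600 nM

Among the compounds with values here, in a functional assay on A549 cells (Homo sapiens) for inhibition, read by MTT assay, with a stated time of 72 h (a higher number here means a weaker inhibitor, a lower number a stronger inhibitor), compound 2 gives 25600 nM, which lies within the scatter of compound 1, the only other compound measured. Compound 3 `CC(C)(C)c1ccc(CN2CCc3ncn(COCc4ccccc4)c3/C(=C/c3ccccc3)C2=O)cc1` keeps the shared core and carries 4-(tert-butyl)phenyl in place of 2-methylphenyl on a saturated chain carbon bound to an amide-type nitrogen in a ring. Within the data shown here, one measured step bears on this change at that same place: a 1.4-fold higher number from compound 1 to compound 2 (0.15 log units; within the scatter). It stayed within the scatter, so no step beyond the scatter is expected here. The expected step is a 1.2-fold lower number from compound 2 to compound 3 (0.09 log units; within the scatter). Compound 3 is estimated at 21000 nM, with a range of 10000 nM to 42000 nM.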

Compound 3, half-maximal inhibitory concentration: 20600 nM
For compound 3 the middle estimate is 1.0-fold (0.01 log units) above the measured one, and the stated range covers the measured number.
By their numbers in this assay, from the lowest: compounds 1, 3 and 2 (each within the scatter of the next).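

In this assay, 4-(tert-butyl)phenyl in place of 2-methylphenyl on a saturated chain carbon bound to an amide-type nitrogen in a ring gives one step (a 1.2-fold lower number from compound 2 to compound 3 (0.09 log units; within the scatter)), and tert-butyl in place of phenyl on an aromatic carbon gives another (a 1.1-fold higher number from compound 1 to compound 3 (0.05 log units; within the scatter)). All three groups tried at this place now read within the scatter of one another, so changing the group here has not yet moved the number measurably. Nothing available gives a reason for this. As far as these compounds go, whether an amine or a carboxylic acid on this benzyl ring would shift the number remains open. So does the effect of a longer chain between the ring and the amide-type nitrogen.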